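Hydrazone series: hydroxy to fluoro on the benzoyl ring

This account rests on a few compounds, and the source may have more. Where it says the series, first, only, none or still open, it means among the compounds named here.

Measured compounds:
compound 1, `O=C(N/N=C/c1cc(I)cc(I)c1O)c1ccc(O)cc1`, 19200 nM
compound 2, `O=C(N/N=C/c1cc(I)cc(I)c1O)c1ccc(F)cc1`, 12100 nM
compound 3, `O=C(N/N=C/c1cc(I)c(O)c(I)c1)c1ccc(O)cc1`, 110000 nM

In a functional assay on HepG2 cells (Homo sapiens) for cytotoxicity, with a stated time of 24 h (on this read-out higher numbers stand for weaker inhibition and lower numbers for stronger inhibition), compound 1 gives 19200 nM and compound 2 gives 12100 nM. The change between them is fluoro in place of hydroxy on an aromatic carbon, and it made a 1.6-fold lower number from compound 1 to compound 2 (0.20 log units; within the scatter), so the two numbers are not separated by this assay. Compound 3 gives 110000 nM in this assay, the highest of the three numbers; the difference between its core and the core of compound 1 is not broken down here.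

Compound 4, `O=C(N/N=C/c1cc(I)c(O)c(I)c1)c1ccc(F)cc1`, has not been measured. It differs from compound 3 by fluoro in place of hydroxy on an aromatic carbon, the same change as from compound 1 to compound 2, at a place described in identical words. For the measured compounds named here, the step from compound 3 to compound 4 is expected to be about a 1.6-fold lower number from compound 3 to compound 4 (0.20 log units; within the scatter) in this assay, resting on the one earlier instance, which stayed within the scatter. Compound 4 is therefore estimated at 70000 nM in this assay, with a range from 30000 nM to 160000 nM.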

Compound 4, half-maximal inhibitory concentration: 117000 nM
The estimate for compound 4 lay 1.7-fold (0.22 log units) below the measured number; the measured number falls inside the stated range.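

In this assay, the change from 4-hydroxyphenyl to 4-fluorophenyl gave a 1.1-fold higher number from compound 3 to compound 4 (0.03 log units; within the scatter), so this assay does not separate the two numbers on this core. Set beside the earlier step, the change shows no detectable difference between the two cores: the same change on two cores in this assay, a 1.6-fold lower number (0.20 log units; within the scatter) from compound 1 to compound 2 and a 1.1-fold higher number (0.03 log units; within the scatter) from compound 3 to compound 4, 1.7-fold (0.23 log units) apart, within the scatter of two such steps This supports carrying the change between these two cores only when the expected outcome is a step within the scatter; with just two pairs in a single assay, it does not show that the same would hold on any other core, nor does it explain why neither step moved beyond the scatter.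

The compounds shown carry only hydroxy or fluoro at this place, so it remains open whether an amine, a carboxylic acid or a methoxy group there would give a step beyond the scatter. On these data alone, it also remains open whether the change would stay this small if chlorine or bromine took the place of the iodine atoms on the other ring.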